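The source may report more compounds than this note shows. Statements on the series, on what has been measured and on what is new or still open speak of the compounds shown alone.

In a functional assay on KB cells (Homo sapiens) for inhibition, read by MTT assay, with a stated time of 24 h, tested at 10 ug/mL (on this read-out higher numbers stand for more inhibition of growth at the one concentration tested and lower numbers for less inhibition of growth), compound 2 `O=C(CCCCC(S)CCS)Nc1ccccn1` gives 0.28%, the lower of the two numbers available. Compound 1 `O=C(CCCCC1CCSS1)Nc1ccc(Cl)cn1` gives 28.6%, and the gap between them lies beyond the usual scatter. Compound 3 `O=C(CCCCC(S)CCS)Nc1ccc(Cl)cn1` differs from compound 2 by one change, chloro in place of hydrogen on an aromatic carbon. Compound 1 also bears this chloro and gives 28.6%, so a rise in inhibition is expected. The expected change, a number 13.7 percentage points higher from compound 2 to compound 3 (beyond the scatter), is an estimated increase beyond the scatter. Compound 3 is estimated at 14%, with an expected range from 2% to 32%.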

Compound 3, percent growth inhibition at one concentration: 21.6%
Compound 3: middle estimate off by 7.6 percentage points, on the low side; low and high end bracket the measured number.
By their numbers in this assay, from the lowest: compound 2; then compounds 3 and 1 (each within the scatter of the next).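

In this assay, the chloro two atoms from the ring nitrogen now has a direct one-place comparison on the open chain, and it counts on its own (a number 21.3 percentage points higher from compound 2 to compound 3 (beyond the scatter)). With chloro in place, the open chain and the five-membered ring with two sulfurs cannot be told apart (a number 7 percentage points lower from compound 1 to compound 3 (within the scatter)). Nothing available explains the chloro step. The compounds shown leave open whether fluoro, bromo or methyl at this position would read the same. They also leave open how the ring form without chloro would read.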